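The source may hold more compounds than are shown below. What is called first, only, known or untested is meant among the compounds shown, and "the series" means these compounds.

Measured compounds:
Compound 1 `CCOC(=O)C1=Cc2ccccc2OC1(OCc1cc(-c2ccc(C)cc2)no1)C(F)(F)F` gives in a functional assay on MCF7 cells (Homo sapiens) for inhibition, read by MTT assay, with a stated time of 24 h (on this read-out lower numbers stand for stronger inhibition and higher numbers for weaker inhibition), a number recorded only as a limit, > 150000 nM.
Compound 2 `Cc1ccc(-c2cc(COC3(C(F)(F)F)Oc4ccccc4C=C3C(=O)O)on2)cc1` gives in this assay a value of 30100 nM.
Compound 3 `CCOC(=O)C1=Cc2ccccc2OC1(OCc1cn(CC(=O)Nc2ccc(OC)cc2)nn1)C(F)(F)F` gives in this assay a value of 28100 nM.

Compound 1 stands at the edge of what this assay can report: its entry is a limit and not a measured number, (the limit of > 150000 nM in this assay, at which 1 of the 3 values shown sits). Among the measured compounds shown here, only one step within the measured set can be read, an at least 4.9-fold lower number from compound 1 to compound 2 (0.69 log units; beyond the scatter), and it concerns the ester oxygen, not the aromatic ring at the far end of the molecule.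

Compound 4 `CCOC(=O)C1=Cc2ccccc2OC1(OCc1cc(-c2ccc([N+](=O)[O-])cc2)no1)C(F)(F)F` differs from compound 1 by nitro in place of methyl on an aromatic carbon. For the measured compounds named here, none of the measured steps touches this position, so the measured data give no size for such a change, in either direction. Going by the values given here, compound 3 carries an ethyl ester like compound 1 and still gives a measured number, so an ester alone does not force the limit, but its ring system is different and no step between the two is defined.

With compound 1 itself at the limit, any expectation for compound 4 is loose. Compound 4 is estimated to give about 100000 nM in this assay, within 25000 nM to 400000 nM. This corresponds to an expected at least 1.5-fold lower number from compound 1 to compound 4 (0.17 log units; that floor lies within the scatter). A sizeable chance remains that this assay again reports only a limit for compound 4.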

Compound 4, half-maximal inhibitory concentration: > 150000 nM
Compound 4: a limit, no number; the forecaster's own chance of this, stated with the estimate: 45%; middle value at least 1.5-fold (0.17 log units) from the limit.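

Compound 4 is recorded in this assay only as a limit, > 150000 nM. Compound 1 also has only a limit there, so no step can be read between compound 1 and compound 4. The compounds shown leave open whether changing 4-methylphenyl to 4-nitrophenyl shifts the number in this assay at all, and by how much.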